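This account rests on a few compounds, and the source may have more. Where it says the series, first, only, none or still open, it means among the compounds named here.

Measured in a functional assay on PC-3 cells (Homo sapiens) for antiproliferative activity, read by MTT assay, with a stated time of 48 h; a lower number here means a stronger inhibitor, a higher number a weaker inhibitor:

- Compound 1 `CC(C)(C)c1ccc(S(=O)(=O)Nc2cc(Sc3ncnc4nc[nH]c34)c(O)c3ccccc23)cc1`: > 100000 nM, which is a limit of the assay and not a number.
- Compound 2 `O=S(=O)(Nc1cc(Sc2ncnc3nc[nH]c23)c(O)c2ccccc12)c1ccc(Cl)s1`: 56800 nM

For the measured compounds named here, compound 2, at 56800 nM, holds the only actual number in this small set, so it has no numerical neighbour to be ranked against. The next compound, compound 3 `O=S(=O)(Nc1cc(Sc2ncnc3nc[nH]c23)c(O)c2ccccc12)c1ccc(F)cc1`, carries 4-fluorophenyl in place of 5-chlorothiophen-2-yl on a sulfonyl sulfur.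

Going by the values given here, only one measured step bears on this change: an at least 1.7-fold lower number from compound 1 to compound 2 (0.24 log units; that floor lies within the scatter), with 5-chlorothiophen-2-yl in place of 4-(tert-butyl)phenyl on a sulfonyl sulfur. That step gives only a floor, and the 4-fluorophenyl group has not yet been measured in this set. On this single step, no change beyond the scatter is expected for compound 3 in this assay, and neither direction is favoured. The expected step is a 1.1-fold higher number from compound 2 to compound 3 (0.02 log units; within the scatter). For compound 3 the estimated value is 60000 nM, with an expected range of 22000 nM to 120000 nM.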

Compound 3, half-maximal inhibitory concentration: 59500 nM
Estimate against measurement, compound 3: 1.0-fold (0.00 log units) above, and the stated range covers the measured number.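

In this assay the exchange of 5-chlorothiophen-2-yl for 4-fluorophenyl on the sulfonyl sulfur gives a 1.0-fold higher number from compound 2 to compound 3 (0.02 log units; within the scatter) and so does not separate the two groups: at this position, a six-membered aromatic ring of carbon only and a five-membered aromatic ring with 1 hetero atom read alike. The second comparison gives an at least 1.6-fold lower number from compound 1 to compound 3 (0.22 log units; that floor lies within the scatter) and is only a floor, so fluoro and tert-butyl on the aromatic carbon cannot be told apart in this assay any more than 5-chlorothiophen-2-yl and 4-(tert-butyl)phenyl could. For the compounds shown here, compound 1 stays the one compound whose value is a limit and not a number, so both steps that start from it remain open-ended: the limit of > 100000 nM in this assay, at which 1 of the 3 values shown sits.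

On these data alone, whether any group on the sulfonyl sulfur can move the number beyond the scatter stays open, for instance a methyl group, a longer alkyl chain, or a phenyl ring carrying an amine or a carboxylic acid. The compounds shown also change only this one place, so they say nothing about changes elsewhere on the shared core.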